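Amide nitrogen substituent and tolerated concentration

This account rests on a few compounds, and the source may have more. Where it says the series, first, only, none or still open, it means among the compounds named here.

Among the measured compounds shown here, compound 3 `COc1ccc2nc(C)cc(OCC(=O)NCCCc3ccccc3)c2c1` is the only member of the series with a number in an ADME assay on HepG2 cells (Homo sapiens) for cytotoxicity, read by trypan blue exclusion, with a stated time of 48 h, in the presence of a further agent that is not named here; a higher number here means that more compound is tolerated, a lower number that less compound is tolerated: compound 3 gives 50700 nM. Compound 1 `COc1ccc2nc(C)cc(OCC(=O)Nc3ccc(Br)cc3)c2c1` reaches only a limit of the assay, > 125000 nM. Compound 2 `COc1ccc2nc(C)cc(OCC(=O)Nc3ccccc3Cl)c2c1` likewise reaches only a limit, > 140000 nM. The step that the two limits leave unreadable from compound 1 to compound 2 cannot be read. The steps of an at least 2.4-fold lower number from compound 1 to compound 3 (0.39 log units; beyond the scatter) and an at least 2.7-fold lower number from compound 2 to compound 3 (0.44 log units; beyond the scatter) show that the aryl amides are tolerated to the limits the limit of > 125000 nM in this assay, at which 1 of the 3 values shown sits, and the limit of > 140000 nM in this assay, at which 1 of the 3 values shown sits, while the alkyl-linked amide is not.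

Compound 4 `CCCCCNC(=O)COc1cc(C)nc2ccc(OC)cc12` differs from compound 3 by ethyl in place of phenyl on a saturated chain carbon, three bonds along the chain from an amide-type nitrogen. For the measured compounds named here, no measured step covers a change within the alkyl chain itself; the two readable steps only contrast aryl amides with a chain-linked one. The change keeps the chain, so a step in this assay of small size, if any, is expected, and the direction is open.

For compound 4 an estimate of 65000 nM is made, with a range from 25000 nM to 160000 nM. This estimate means an expected step of a 1.3-fold higher number from compound 3 to compound 4 (0.11 log units; within the scatter) in this assay.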

Compound 4, half-maximal cytotoxic concentration: 106000 nM
The estimate for compound 4 lay 1.6-fold (0.21 log units) below the measured number; the range from low to high includes it.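

In this assay, the change of place on a saturated chain carbon, three bonds along the chain from an amide-type nitrogen, gives a 2.1-fold higher number from compound 3 to compound 4 (0.32 log units; beyond the scatter), so a chain-linked amide does not by itself carry the lower number seen for compound 3. The two comparisons with the aryl amides each start from a limit of the assay, and they read an at least 1.3-fold lower number from compound 2 to compound 4 (0.12 log units; that floor lies within the scatter) and an at least 1.1-fold lower number from compound 1 to compound 4 (0.07 log units; that floor lies within the scatter), which leaves compound 4 not separated from either. The earlier contrast between aryl amides and a chain-linked amide therefore holds for compound 3, while compound 4 goes against it as a general pattern.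

Open, on these data alone, is whether benzyl, phenethyl, propyl, butyl or a longer chain such as octyl would sit nearer compound 3 or compound 4. Also open, as far as these compounds go, is how an amine or a carboxylic acid on the chain would read.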